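The source may hold more compounds than are shown below. What is called first, only, known or untested is meant among the compounds shown, and "the series" means these compounds.

Values in a functional assay on IMR-32 cells (Homo sapiens) for cytotoxicity, read by sulforhodamine B assay, with a stated time of 48 h (on this read-out lower numbers stand for stronger inhibition and higher numbers for weaker inhibition), so far
- Compound 1 `C=CCOc1c(Cl)cccc1C(=O)c1cccnc1` gives 94000 nM
- Compound 2 `O=C(c1cccnc1)c1cc(Cl)cc(Cl)c1O` gives 28800 nM

Compound 2 holds the lower of the two numbers, and the gap to compound 1 lies beyond the scatter. Compound 3 `O=C(c1cccnc1)c1cccc(Cl)c1O` differs from compound 2 by hydrogen in place of chloro on an aromatic carbon in one place. Going by the values given here, no measured pair shows this change alone. A modest rise in the number is expected, toward weaker inhibition and near the edge of the scatter, since compound 1 with hydrogen at that place reads 94000 nM on a different core. The expected move is a 1.7-fold higher number from compound 2 to compound 3 (0.24 log units; within the scatter) in this estimate. For compound 3 the estimated value is 50000 nM with a range of 20000 nM to 120000 nM around it.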

Compound 3, half-maximal inhibitory concentration: 26000 nM
Estimate against measurement, compound 3: 1.9-fold (0.28 log units) above, and the stated range covers the measured number.
By their numbers in this assay, from the lowest: compounds 3 and 2 (each within the scatter of the next); then compound 1.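

In this assay hydrogen and chloro on the aromatic carbon para to the hydroxy group read alike (a 1.1-fold lower number from compound 2 to compound 3 (0.04 log units; within the scatter)), so the chloro at this place makes no difference beyond the scatter on the shared core. Hydrogen in place of allyl on the oxygen, by contrast, gives a step beyond the scatter (a 3.6-fold lower number from compound 1 to compound 3 (0.56 log units; beyond the scatter)). Nothing available accounts for either step. Going by these compounds, whether an amine or a methoxy group at this place would also read like hydrogen and chloro stays open. So does how a methyl group on the oxygen would compare with allyl and hydrogen.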